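This account rests on a few compounds, and the source may have more. Where it says the series, first, only, none or still open, it means among the compounds named here.

Measured so far in an ADME assay on a cell-free system (serum, Homo sapiens) for metabolic stability; on this read-out lower numbers stand for a shorter-lived compound and higher numbers for a longer-lived compound:
compound 1 `O=C(CCCO[N+](=O)[O-])Oc1ccccc1C(=O)O` — 0.47 h
compound 2 `O=C(CCCCC(CO[N+](=O)[O-])O[N+](=O)[O-])Oc1ccccc1C(=O)O` — 6.25 h
compound 3 `CC(C)(CO[N+](=O)[O-])C(=O)Oc1ccccc1C(=O)O` — 9.03 h

Compound 2 stands second highest of the three numbers in this assay; compound 3 is nearest, within the scatter, and compound 1 is furthest, beyond the scatter. Compound 4 `O=C(CCCCCCO[N+](=O)[O-])Oc1ccccc1C(=O)O` is not yet measured. Against compound 2 the change is hydrogen in place of nitrooxy on a saturated chain carbon bound to two saturated chain carbons. For the measured compounds named here, no measured pair shares this change, so its size is open. Going by the values given here, the only compound with a single nitrooxy, compound 1, gives the lowest number in this assay, which points to a decrease for compound 4 beyond the scatter, though its chain is longer than that of compound 1. The expected step of a 2.5-fold lower number from compound 2 to compound 4 (0.40 log units; beyond the scatter) is a moderate decrease. For compound 4 the expected value in this assay is 2.5 h, within 0.8 h to 7 h.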

Compound 4, half-life in the serum assay: 1.19 h
The estimate for compound 4 lay 2.1-fold (0.32 log units) above the measured number; the measured number falls inside the stated range.
By their numbers in the serum assay, from the lowest: compound 1; then compound 4; then compounds 2 and 3 (each within the scatter of the next).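

In the serum assay, hydrogen in place of nitrooxy on a saturated chain carbon bound to two saturated chain carbons gives a 5.3-fold lower number from compound 2 to compound 4 (0.72 log units; beyond the scatter) as the first measured size for this change, while 3-(nitrooxy)propyl in place of nitrooxy on a saturated chain carbon, three bonds along the chain from a carbonyl carbon, gives a 2.5-fold higher number from compound 1 to compound 4 (0.40 log units; beyond the scatter) in the same read-out. In a physicochemical assay for acid dissociation, compound 2 gives 3.69 and compound 4 gives 3.69 with no change at the digits printed.

On these data alone, whether an amine or a carboxylic acid at this carbon would give a similar step in the serum assay remains open. Nothing available accounts for either step in half-life.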